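Halogen swap on the aryl imine of compound 2

The compounds below may be only part of what the source reports. "The series", "measured", "known", "first", "only" and "open" are said of these compounds alone.

Measured compounds in an assay on HEK293 cells for displacement of a labelled ligand from adenosine receptor A1 (Homo sapiens), read by scintillation counting, with a stated time of 60 min; on this read-out lower numbers stand for stronger inhibition and higher numbers for weaker inhibition:
compound 1 `CCn1c(/N=C/c2ccc(Cl)cc2)c(C#N)sc1=S`: 19.8 nM
compound 2 `CCCn1c(/N=C/c2ccc(Cl)cc2)c(C#N)sc1=S`: 2.32 nM
compound 3 `N#Cc1sc(=S)n(-c2ccccc2)c1/N=C/c1ccc(Cl)cc1`: 413 nM

Compound 2 gives the lowest number of the three. The nearest is compound 1, separated by an 8.5-fold lower number from compound 1 to compound 2 (0.93 log units; beyond the scatter); the furthest is compound 3, separated by a 180-fold higher number from compound 2 to compound 3 (2.25 log units; beyond the scatter). Compound 1 and compound 3 are separated by a 21-fold higher number from compound 1 to compound 3 (1.32 log units; beyond the scatter). All three steps change only the substituent on the aromatic nitrogen of the shared core.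

Compound 4 `CCCn1c(/N=C/c2ccc(Br)cc2)c(C#N)sc1=S` is not yet measured. It differs from compound 2 by bromo in place of chloro on an aromatic carbon. Going by the values given here, no measured step touches this part of the molecule: the ethyl-to-propyl change, an 8.5-fold lower number from compound 1 to compound 2 (0.93 log units; beyond the scatter), and the two replacements by phenyl, a 21-fold higher number from compound 1 to compound 3 (1.32 log units; beyond the scatter) and a 180-fold higher number from compound 2 to compound 3 (2.25 log units; beyond the scatter), all sit on the aromatic nitrogen and give no direct read on a halogen exchange on the six-membered aromatic ring. The starting point is compound 2 at 2.32 nM. With nothing in the series speaking for a shift, the expected step is a 1.1-fold higher number from compound 2 to compound 4 (0.03 log units; within the scatter), not beyond the scatter. Compound 4 is therefore estimated at 2.5 nM in this assay, with a range from 0.8 nM to 8 nM.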

Compound 4, inhibition constant: 607 nM
The estimate for compound 4 lay 240-fold (2.39 log units) below the measured number; measured number outside the range, above it.
By their numbers in this assay, from the lowest: compound 2; then compound 1; then compounds 3 and 4 (each within the scatter of the next).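

Notes on the halogen position, read in this assay: the position para to a large group on the six-membered aromatic ring is not neutral to a change of halogen, since bromo in place of chloro gives a 260-fold higher number from compound 2 to compound 4 (2.42 log units; beyond the scatter) and thus a large step beyond the scatter. The exchange replaces one heavy atom with one heavy atom and leaves the ring count, hydrogen-bond donors, hydrogen-bond acceptors and net charge unchanged, so large steps in this series are no longer confined to the substituent on the aromatic nitrogen, where a 180-fold higher number from compound 2 to compound 3 (2.25 log units; beyond the scatter) was the largest seen before. No measurement in hand accounts for the size of this step.

Going by these compounds, it remains open whether the step belongs to bromo alone or to any departure from chloro at this place, and fluoro, methyl or methoxy there, or a plain hydrogen, would separate those two readings. On these data alone, it also remains open whether the same exchange carries a step of similar size with ethyl or phenyl on the aromatic nitrogen, as in compound 1 and compound 3.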